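This account rests on a few compounds, and the source may have more. Where it says the series, first, only, none or still open, it means among the compounds named here.

Measured compounds in an ADME assay on NIH3T3 cells (Mus musculus) for cytotoxicity, read by XTT assay, with a stated time of 24 h; on this read-out lower numbers stand for stronger inhibition and higher numbers for weaker inhibition:

Compound 1, `Cn1nnnc1SCC(=O)N/N=C/c1ccc(Cl)cc1`: 2100000 nM
Compound 2, `Cn1nnnc1SCC(=O)N/N=C/c1ccc(Br)cc1`: 10000000 nM
Compound 3, `Cn1nnnc1SCC(=O)N/N=C/c1cccc(Cl)c1`: 7500000 nM

The three measured compounds share one core, and the set is to be extended by compound 4, `Cn1nnnc1SCC(=O)N/N=C/c1cccc(Br)c1`, which is not yet measured in this assay.

Compound 1 and compound 2 differ by a single change, (bromo in place of chloro on an aromatic carbon). In this assay this change produced a 4.8-fold higher number from compound 1 to compound 2 (0.68 log units; beyond the scatter). Compound 3 carries the same core as compound 1 but with its atoms joined differently; the difference between these two cores is not broken down here. Compared with compound 2, compound 3 gives a number that lies within the scatter, so the two are not distinguishable in this assay; against compound 1 the value of compound 3 is beyond the scatter.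

Compound 4 stands to compound 3 as compound 2 stands to compound 1: the change is bromo in place of chloro on an aromatic carbon. Going by the values given here, it is the same kind of change as the one from compound 1 to compound 2, but the place differs: in the first pair the bromo sits para to a large group, in the second pair it sits meta to a large group. Among the compounds with values here, the earlier step gives the only guide. Because a 4.8-fold higher number from compound 1 to compound 2 (0.68 log units; beyond the scatter) went upward by a modest amount, compound 4 is expected to give a higher number than compound 3, and the expected step is a 2.0-fold higher number from compound 3 to compound 4 (0.30 log units; within the scatter), somewhat damped since compound 3 already starts high in this assay. Compound 4 is estimated at 15000000 nM, between 5000000 nM and 45000000 nM.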

Compound 4, half-maximal inhibitory concentration: 316000 nM
Beside the measured number, compound 4's estimate is 47-fold (1.68 log units) above it; measured number outside the range, below it.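

Bromo in place of chloro on an aromatic carbon did not behave alike on the two cores in this assay, where the two steps differ in direction as well as in size: the same change on two cores in this assay, a 4.8-fold higher number (0.68 log units; beyond the scatter) from compound 1 to compound 2 and a 24-fold lower number (1.38 log units; beyond the scatter) from compound 3 to compound 4, 110-fold (2.05 log units) apart, beyond the scatter of two such steps

With the change meta to a large group, the exchange gives a 24-fold lower number from compound 3 to compound 4 (1.38 log units; beyond the scatter), so the step read on the core of compound 1 could not be carried over to the core of compound 3, not even in its sign. This does not show why the two steps part, and with a single pair on each core it cannot separate the place of the halogen on the ring from anything else that differs between the two cores, nor can it say how the same exchange would run on a third core.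

The compounds shown carry only chloro and bromo on the ring, which leaves open what fluoro, methoxy or an amine would give at either place in this assay. They also leave open whether the opposite steps would persist with a longer chain in place of the methyl on the shared core.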